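From dibutylamino to dipentylamino: compound 2 to compound 3

The compounds below may be only part of what the source reports. "The series", "measured", "known", "first", "only" and "open" are said of these compounds alone.

Measured in a functional assay on DU-145 cells (Homo sapiens) for antiproliferative activity, read by WST assay, with a stated time of 3 days; on this read-out higher numbers stand for weaker inhibition and lower numbers for stronger inhibition:
- compound 1 `CCCCOc1c(-c2cc(OC)c(OC)c(OC)c2)oc2ccccc2c1=O`: > 50000 nM
- compound 2 `CCCCN(CCCC)CCCCOc1c(-c2cc(OC)c(OC)c(OC)c2)oc2ccccc2c1=O`: 15300 nM

The entry for compound 1 is a limit of the assay and not a number. Compound 2 therefore stands alone with a true number, 15300 nM, and it has no other number to be ranked against.

Compound 3 `CCCCCN(CCCCC)CCCCOc1c(-c2cc(OC)c(OC)c(OC)c2)oc2ccccc2c1=O` carries dipentylamino in place of dibutylamino on a saturated chain carbon, four bonds along the chain from an oxygen on an aromatic ring, with dipentylamino in place of dibutylamino on a saturated chain carbon, four bonds along the chain from an oxygen on an aromatic ring.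

Within the data shown here, only one measured step bears on this change: an at least 3.2-fold lower number from compound 1 to compound 2 (0.51 log units; beyond the scatter). That step introduced the amino group and did not vary it, so it offers weak guidance. A small move to a lower number in this assay is expected, possibly within the scatter. The estimated step is a 1.5-fold lower number from compound 2 to compound 3 (0.18 log units; within the scatter). For compound 3 the expected value is 10000 nM, with an estimated range of 3500 nM to 30000 nM.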

Compound 3, half-maximal inhibitory concentration: 12500 nM
The estimate for compound 3 lay 1.3-fold (0.10 log units) below the measured number; measured number inside the range.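

In this assay, the move from dibutylamino to dipentylamino gives a 1.2-fold lower number from compound 2 to compound 3 (0.09 log units; within the scatter), so at this position the added chain length in the two amine substituents does not separate the two compounds beyond the scatter. Replacing hydrogen with dipentylamino at this place gives an at least 4.0-fold lower number from compound 1 to compound 3 (0.60 log units; beyond the scatter), which shows that a second amine keeps the lower number seen with dibutylamino. Compound 1 is a limit of the assay and not a number, so this step has only a lower bound: the limit of > 50000 nM in this assay, at which 1 of the 3 values shown sits.

Going by these compounds, whether a small amine such as dimethylamino, or a ring amine such as piperidine or morpholine, would behave like these two open-chain amines stays open. Among these compounds, also open is whether a shorter or longer linking chain than the one shared by compound 2 and compound 3 would move the number beyond the scatter.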